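Trimming Pentyl to Butyl: an Expected Shift in Lipophilicity

This account rests on a few compounds, and the source may have more. Where it says the series, first, only, none or still open, it means among the compounds named here.

Measured so far:
compound 1, `CCCCCc1ccc2c(c1)c([N+](=O)[O-])cc[n+]2[O-]`: 3.26
compound 2, `Cc1ccc2c([N+](=O)[O-])cc[n+]([O-])c2c1`: 1.49

Both numbers come from a physicochemical assay for lipophilicity; a higher number here means a more lipophilic compound, a lower number a more polar compound. Within the data shown here, of the two, compound 1 holds the higher value; compound 2, its only neighbour, sits well below it, and that gap lies beyond the usual scatter. Compound 3, `CCCCc1ccc2c(c1)c([N+](=O)[O-])cc[n+]2[O-]`, has not been measured. It differs from compound 1 in one place: hydrogen in place of methyl on a saturated chain carbon, four bonds along the chain from an aromatic carbon. Cut one bond further out, the same difference reads butyl to propyl, propyl to ethyl, or ethyl to methyl. Among the measured compounds shown here, no pair of measured compounds shows this step, so its size in this assay cannot be read off the data. What the change does is remove the methyl that leaves and put hydrogen in its place, so a modest fall is expected in this assay, likely beyond the scatter, leaving compound 3 below compound 1. Compound 3 is therefore estimated at 2.75, within 2.4 to 3.1. The step this estimate implies is a number 0.51 log units lower from compound 1 to compound 3 (beyond the scatter).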

Compound 3, partition coefficient: 3.11
Compound 3: the middle estimate sits 0.36 log units below what was measured; the whole stated range lies below it.
By their numbers in this assay, from the lowest: compound 2; then compounds 3 and 1 (each within the scatter of the next).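

Hydrogen in place of methyl on a saturated chain carbon, four bonds along the chain from an aromatic carbon, gives the only step here between compounds that differ in one place: in this assay it reads a number 0.15 log units lower from compound 1 to compound 3 (within the scatter) for the trim from pentyl to butyl. This measurement therefore does not tell compound 1 and compound 3 apart, which shows that this single change, at this place on the shared core, does not produce a difference larger than repeated measurements would. Nothing at hand offers an explanation for the size of this step.

The compounds shown leave open whether the same change gives a similar step further down the chain, as butyl to propyl, propyl to ethyl or ethyl to methyl, and whether several such changes taken together would reach beyond the scatter. They also leave open what a longer chain, or an amine or a carboxylic acid in the same place, would read in this assay.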